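The source may report more compounds than this note shows. Statements on the series, on what has been measured and on what is new or still open speak of the compounds shown alone.

Measured compounds in a functional assay on MCF7 cells (Homo sapiens) for cytotoxicity, read by MTT assay, with a stated time of 48 h; on this read-out lower numbers stand for stronger inhibition and higher numbers for weaker inhibition:

Compound 1 `Fc1cccc(-c2nc(Nc3ccccc3)c3ccccc3n2)c1`: > 50000 nM, a limit of this assay.
Compound 2 `Fc1ccc2nc(-c3ccccc3)nc(Nc3ccccc3)c2c1`: > 50000 nM, a limit of this assay.
Compound 3 `Fc1ccc(Nc2nc(-c3cccc(F)c3)nc3ccc(F)cc23)cc1`: > 50000 nM, a limit of this assay.

Compound 3 therefore stands at the limit of this assay, and the two further values sit there too, as the limit of > 50000 nM in this assay, at which 3 of the 3 values shown sit, records. No numbered step between measured compounds exists, so the three structures can only be read as all lying at the limit.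

Compound 4 `Fc1cccc(-c2nc(Nc3ccc(Br)cc3)c3cc(F)ccc3n2)c1` differs from compound 3 by bromo in place of fluoro on an aromatic carbon. With every measured value at the limit, the step from compound 3 to compound 4 in this assay is expected to be none beyond the scatter, as a step that the limit leaves unreadable from compound 3 to compound 4 expresses. Compound 4 is accordingly estimated at 60000 nM, within a range from 20000 nM to 200000 nM, with a limit remaining the likeliest outcome.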

Compound 4, half-maximal inhibitory concentration: > 50000 nM
Compound 4: only a limit was reported; the forecaster's own chance of this, stated with the estimate: 75%; the middle value is on the limit's open side.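

Among these compounds, compound 3 and compound 4 each give only a limit in this assay, and no step between them can be read. The compounds shown leave open whether any change to their groups would give a measured value rather than a limit.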